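Removing a methoxy: expected growth inhibition of compound 4

The source may report more compounds than this note shows. Statements on the series, on what has been measured and on what is new or still open speak of the compounds shown alone.

Compound 1 `COc1ccc(-c2[nH]c3ccccc3c2/C=C(\C#N)S(=O)(=O)c2ccccc2)cc1`: in a functional assay on PC-3 cells (Homo sapiens) for inhibition, read by sulforhodamine B assay, with a stated time of 48 h (on this read-out higher numbers stand for weaker inhibition of growth and lower numbers for stronger inhibition of growth), compound 1 gives 557 nM.
Compound 2 `COc1ccc(-c2[nH]c3ccc(OC)cc3c2/C=C(\C#N)S(=O)(=O)c2ccccc2)cc1`: in this assay compound 2 gives 534 nM.
Compound 3 `COc1ccc(-c2[nH]c3ccc(OC)cc3c2C=C(C#N)C#N)cc1`: in this assay compound 3 gives 342 nM.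

Compound 2 sits second highest among these three numbers; compound 1 is nearest and compound 3 furthest, yet both lie within the scatter of compound 2. Compound 4 `COc1ccc2[nH]c(-c3ccccc3)c(/C=C(\C#N)S(=O)(=O)c3ccccc3)c2c1` differs from compound 2 by hydrogen in place of methoxy on an aromatic carbon. For the measured compounds named here, the only measured single change is a 1.0-fold lower number from compound 1 to compound 2 (0.02 log units; within the scatter), a methoxy added on a different aromatic carbon of the shared core, which moved the number within the scatter. Compound 3, which differs from compound 2 elsewhere, also lies within the scatter. A change of the same kind at another place is therefore expected to give no step beyond the scatter in this assay, a 1.1-fold higher number from compound 2 to compound 4 (0.05 log units; within the scatter). Compound 4 is expected to give 600 nM, between 250 nM and 1500 nM.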

Compound 4, concentration for 50% growth inhibition: 8300 nM
Compound 4: middle estimate off by 14-fold (1.14 log units), on the low side; measured number above the stated range.
By their numbers in this assay, from the lowest: compounds 3, 2 and 1 (each within the scatter of the next); then compound 4.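

Going from 4-methoxyphenyl to phenyl gives a 16-fold higher number from compound 2 to compound 4 (1.19 log units; beyond the scatter) in this assay, so growth inhibition in this series depends strongly on this methoxy. The methoxy on another aromatic carbon of the shared core gave only a 1.0-fold lower number from compound 1 to compound 2 (0.02 log units; within the scatter), so the same group can count for little at one place and for much at another. The data shown offer no explanation for this difference.

On these data alone, whether a hydroxyl, an ethoxy or a chlorine at this place would keep the growth inhibition of compound 2 remains open. Also open, as far as these compounds go, is whether losing this methoxy would cost as much in compound 3.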